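Shifting the piperidinyl ether attachment in compound 3

A few compounds are considered here, and "the series" means these few. Any claim that something is new, unique, unknown or untested is made for them only; others in the source may bear on it.

Of the compounds shown here, three carrying a shared core have been measured in a functional assay on HT-29 cells (Homo sapiens) for inhibition, read by MTT assay; a lower number here means a stronger inhibitor, a higher number a weaker inhibitor. Compound 1 `COc1cc2c(Oc3ccc(NC(=O)NN4C(=O)CSC4c4ccc(F)cc4)cc3)ccnc2cc1OC1CCN(C(=O)NCc2ccccc2)CC1` gives 6600 nM. Compound 2 `COc1cc2c(Oc3ccc(NC(=O)NN4C(=O)CSC4c4cccc(F)c4F)cc3)ccnc2cc1OC1CCN(C(=O)NC(C)C)CC1` gives 790 nM. Compound 3 `COc1cc2c(Sc3ccc(NC(=O)NN4C(=O)CSC4c4c(F)cccc4F)cc3)ccnc2cc1OC1CCN(C(=O)NC(C)C)CC1` gives 420 nM, the lowest of the three numbers; compound 2 lies nearest to it, within the usual scatter, while compound 1 lies furthest, beyond the scatter. The new compound 4 `COc1cc2c(Sc3ccc(NC(=O)NN4C(=O)CSC4c4c(F)cccc4F)cc3)ccnc2cc1OC1CCCN(C(=O)NC(C)C)C1` differs from compound 3 in one place only: 1-(isopropylcarbamoyl)piperidin-3-yl in place of 1-(isopropylcarbamoyl)piperidin-4-yl on an oxygen on an aromatic ring. The same atoms are present, joined differently, so the change is a shift of the ether attachment on the piperidine ring. Within the data shown here, no measured pair shows this kind of change, so no step can be drawn from the data. Compound 4 is expected to sit close to compound 3, with a small loss at most, and the step from compound 3 to compound 4 is estimated at a 1.9-fold higher number from compound 3 to compound 4 (0.28 log units; within the scatter). Compound 4 is therefore estimated at 800 nM, within a range from 250 nM to 2500 nM.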

Compound 4, half-maximal inhibitory concentration: > 10000 nM
Compound 4: a limit, no number; the forecaster's own chance of this, stated with the estimate: 3%; middle value at least 12-fold (1.09 log units) from the limit.
By their numbers in this assay, from the lowest: compounds 3 and 2 (each within the scatter of the next); then compound 1. At a limit, above all of these: compound 4.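

In this assay compound 4 gives > 10000 nM, which is a limit of the assay and not a number. Among these compounds, no earlier pair differed in one place, and this first readable step, 1-(isopropylcarbamoyl)piperidin-3-yl in place of 1-(isopropylcarbamoyl)piperidin-4-yl on an oxygen on an aromatic ring, gives an at least 23-fold higher number from compound 3 to compound 4 (1.37 log units; beyond the scatter), showing that this position responds strongly to where the piperidine ring is joined, even though the atoms and the counted features of the group stay the same. The step is itself only a bound: the limit of > 10000 nM in this assay, at which 1 of the 4 values shown sits.

Compound 4 is the only piperidin-3-yl compound shown, so it remains open whether the loss holds with other groups on the ring nitrogen, such as a benzylcarbamoyl group. The same question stands for a free amine or a methyl group in place of the isopropylcarbamoyl group.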